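Carboxy Swapped for Hydroxymethyl on Two Related Cores

A few compounds are considered here, and "the series" means these few. Any claim that something is new, unique, unknown or untested is made for them only; others in the source may bear on it.

Compound 1 `O=C(O)CO/N=C/c1ccc(Cl)cc1` and compound 3 `OCCO/N=C/c1ccc(Cl)cc1` share a core and differ by hydroxymethyl in place of carboxy on a saturated chain carbon bound to an oxygen on an unsaturated carbon. In a functional assay on the whole organism for inhibition, with Rattus norvegicus as the target, read by paw edema, with stated times of 1 h and 3 h (a lower number here means that less compound is needed, a higher number that more compound is needed for the effect), compound 1 gives 45 mg/kg, and compound 3 gives 90 mg/kg; the step reads a 2.0-fold higher number from compound 1 to compound 3 (0.30 log units; within the scatter). Compound 2 `C/C(=N\OCC(=O)O)c1ccc(Cl)s1` rests on another core; the difference between the two cores is not broken down here. In this assay compound 2 gives 34 mg/kg. Compound 4 `C/C(=N\OCCO)c1ccc(Cl)s1` is not yet measured and differs from compound 2 by hydroxymethyl in place of carboxy on a saturated chain carbon bound to an oxygen. The surroundings are not worded alike: for compound 1 the oxygen is bound to an unsaturated carbon, for compound 2 only an oxygen is named, so this is the same kind of change rather than the same change. Compound 4 is expected to show a 2.0-fold higher number from compound 2 to compound 4 (0.30 log units; within the scatter) because the earlier step of a 2.0-fold higher number from compound 1 to compound 3 (0.30 log units; within the scatter) stayed within the scatter. Compound 4 is estimated at 68 mg/kg, probably between 35 mg/kg and 130 mg/kg.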

Compound 4, dose for half-maximal effect: 60 mg/kg
Beside the measured number, compound 4's estimate is 1.1-fold (0.05 log units) above it; the range from low to high includes it.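

In this assay, putting hydroxymethyl in place of carboxy gives a 1.8-fold higher number from compound 2 to compound 4 (0.25 log units; within the scatter). Set side by side, the steps on the two cores agree: the same change on two cores in this assay, a 2.0-fold higher number (0.30 log units; within the scatter) from compound 1 to compound 3 and a 1.8-fold higher number (0.25 log units; within the scatter) from compound 2 to compound 4, 1.1-fold (0.05 log units) apart, within the scatter of two such steps. Going by these compounds alone, this shows that the change behaves alike on these two cores in this assay, but it rests on only two pairs, and neither step lies beyond the scatter, which leaves it unshown that the change itself alters the dose needed.

Other groups on a saturated chain carbon bound to an oxygen remain open, such as an amine or an amide, as does a longer chain in place of 2-hydroxyethyl. From the compounds shown here alone, whether the steps would also agree on a third core is equally open.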